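Swapping the amide partner on a shared benzoxazole-thioether core

A few compounds are considered here, and "the series" means these few. Any claim that something is new, unique, unknown or untested is made for them only; others in the source may bear on it.

Four compounds share the same chain of carbonyl, two saturated carbons and a sulfur attached to the core, and differ in what sits on the carbonyl carbon. Compound 1 `O=C(CCSc1nc2cc(Cl)ccc2o1)N1CCS(=O)(=O)C1` carries a cyclic sulfone amine there; in an ADME assay on microsomes from liver (Mus musculus) for metabolic stability, read by LC-MS, using NADPH, with a stated time of 45 min, tested at 0.5 uM (a lower number here means slower removal, a higher number faster removal of the compound), compound 1 gives 8.9 mL/min/g. Compound 2 `O=C(CCSc1nc(-c2ccccc2)co1)N1CCCC1` has a different core and a pyrrolidine amide; in this assay compound 2 gives "not determined" (no result reported), so no result was reported for it. Compound 3 `O=C(CCSc1nc2cc(Cl)ccc2o1)NC1CCCC1` keeps the chlorinated core of compound 1 and carries a cyclopentylamino group on the carbonyl carbon; in this assay compound 3 gives "not determined" (no result reported), so compound 3 too stands without any number here. The step to compound 4 `CC1CCCN1C(=O)CCSc1nc2cc(Cl)ccc2o1` rearranges the same atoms: 2-methylpyrrolidin-1-yl in place of cyclopentylamino on a carbonyl carbon. Among the compounds with values here, since no measured pair shows a step for this change, only the single value of compound 1 anchors any expectation. Compound 4 is expected to sit somewhat above that anchor in this assay, with wide uncertainty because compound 1 gives 8.9 mL/min/g as the only reference point. The estimate for compound 4 in this assay is 20 mL/min/g, with a likely range from 6 mL/min/g to 60 mL/min/g.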

Compound 4, intrinsic clearance in a liver preparation (reported as CLH), per the amount of preparation that the assay uses: 98 mL/min/g
Compound 4: the middle estimate sits 4.9-fold (0.69 log units) below what was measured; the measured number lies above the stated range.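

In this assay, the group on the carbonyl carbon proves to matter a great deal: with the core and the chain of compound 1 kept unchanged, 2-methylpyrrolidin-1-yl in place of 1,1-dioxo-1,3-thiazolidin-3-yl gives an 11-fold higher number from compound 1 to compound 4 (1.04 log units; beyond the scatter). This position, until now known from a single number, can therefore move the compound from slower to much faster removal through the amide partner alone. No accompanying measurement bears on the reason for this large step, so the result describes a change in the read-out and not its origin.

The steps from compound 3 to compound 4 and from compound 2 to any neighbour cannot be read, since neither compound 2 nor compound 3 carries a number, which leaves the comparison of cyclopentylamino with 2-methylpyrrolidin-1-yl unsettled. As far as these compounds go, it also remains open where other amide partners on the same core, such as morpholin-4-yl or a piperidine ring, would fall, and whether the methyl group on the ring of compound 4 plays any part in the step.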